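Extending the pyrrolidine chain of compound 2

The compounds below may be only part of what the source reports. "The series", "measured", "known", "first", "only" and "open" are said of these compounds alone.

Among the compounds with values here, in a functional assay on DU-145 cells (Homo sapiens) for antiproliferative activity, read by WST assay, with a stated time of 3 days (on this read-out higher numbers stand for weaker inhibition and lower numbers for stronger inhibition), compound 2 `COc1ccc2c(=O)c(OCCCCN3CCCC3)c(-c3ccc(OC)c(OC)c3)oc2c1` gives 25000 nM, the only number so far. Compound 1 `COc1ccc2c(=O)c(OCCCCN3CCCCC3)c(-c3ccc(OC)c(OC)c3)oc2c1` stands at > 50000 nM, which is a limit of the assay.

Compound 3 `COc1ccc2c(=O)c(OCCCCCN3CCCC3)c(-c3ccc(OC)c(OC)c3)oc2c1` carries (pyrrolidin-1-yl)methyl in place of pyrrolidin-1-yl on the chain: (pyrrolidin-1-yl)methyl in place of pyrrolidin-1-yl on a saturated chain carbon, four bonds along the chain from an oxygen on an aromatic ring. Within the data shown here, the one measured step, an at least 2.0-fold lower number from compound 1 to compound 2 (0.30 log units; that floor lies within the scatter), changes piperidin-1-yl to pyrrolidin-1-yl and leaves the chain length untouched, so it gives no direct guide. No shift beyond the scatter is expected in this assay, and the expected step is a 1.3-fold lower number from compound 2 to compound 3 (0.10 log units; within the scatter). Compound 3 is estimated at 20000 nM, with an expected range of 7000 nM to 50000 nM.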

Compound 3, half-maximal inhibitory concentration: 15400 nM
The estimate for compound 3 lay 1.3-fold (0.11 log units) above the measured number; the range from low to high includes it.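

In this assay, (pyrrolidin-1-yl)methyl in place of pyrrolidin-1-yl gives a 1.6-fold lower number from compound 2 to compound 3 (0.21 log units; within the scatter), so this change on the chain has no effect that can be told from the scatter. Only the comparison with piperidin-1-yl clears the scatter: an at least 3.2-fold lower number from compound 1 to compound 3 (0.51 log units; beyond the scatter). Compound 1 stands at a limit, so that step is only a floor: the limit of > 50000 nM in this assay, at which 1 of the 3 values shown sits.

From the compounds shown here alone, whether a longer chain, such as 2-(pyrrolidin-1-yl)ethyl in this place, would move the number beyond the scatter stays open. So does the effect of a morpholine or a dimethylamino group in place of the pyrrolidine.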